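The source may report more compounds than this note shows. Statements on the series, on what has been measured and on what is new or still open speak of the compounds shown alone.

Measured compounds:
compound 1 `COC(=O)c1cccc(C2C(C(=O)O)=C(C)N=C(C)/C2=C(/O)OC/C=C/c2ccccc2)c1`: 4600 nM
compound 2 `CC1=NC(C)=C(C(=O)O)C(c2cccc(I)c2)/C1=C(\O)OC/C=C/c1ccccc1`: 1700 nM

In a functional assay on IMR-32 cells for inhibition of Voltage-dependent N-type calcium channel subunit alpha-1B (Homo sapiens), read by calcium flux (on this read-out higher numbers stand for weaker inhibition and lower numbers for stronger inhibition), compound 1 stands highest of the two numbers. Among the compounds with values here, the single measured step, a 2.7-fold lower number from compound 1 to compound 2 (0.43 log units; beyond the scatter), changes a group on the aromatic ring and shows that a change there can move the number beyond the scatter.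

Compound 3 `CC1=NC(C)=C(C(=O)O)C(c2ccoc2)/C1=C(\O)OC/C=C/c1ccccc1` differs from compound 1 by furan-3-yl in place of 3-(methoxycarbonyl)phenyl on a saturated ring carbon. Within the data shown here, no measured step exchanges the whole aromatic ring, so the one step gives only a rough guide. A small change is expected, a 1.2-fold lower number from compound 1 to compound 3 (0.06 log units; within the scatter). Compound 3 is estimated at 4000 nM, with a range of 1500 nM to 12000 nM.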

Compound 3, half-maximal inhibitory concentration: 11000 nM
For compound 3 the middle estimate is 2.8-fold (0.44 log units) below the measured one; the range from low to high includes it.
By their numbers in this assay, from the lowest: compound 2; then compound 1; then compound 3.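

Exchanging the whole aromatic ring on the saturated ring carbon for furan-3-yl moves the number in this assay upward against both phenyl compounds, giving a 2.4-fold higher number from compound 1 to compound 3 (0.38 log units; beyond the scatter) and also a 6.5-fold higher number from compound 2 to compound 3 (0.81 log units; beyond the scatter). Among these three compounds, both 3-substituted phenyl rings therefore carry lower numbers than the furan-3-yl ring, so this position responds to ring exchange as well as to substituent exchange. No available evidence accounts for the shift.

As far as these compounds go, whether the furan ring itself or the loss of the substituted phenyl ring drives the step stays open. An unsubstituted phenyl, a pyridine or a methyl ester in place of the carboxy group would test this.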